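This account rests on a few compounds, and the source may have more. Where it says the series, first, only, none or still open, it means among the compounds named here.

Among the measured compounds shown here, in a toxicity assay on L02 cells (Homo sapiens) for cytotoxicity, read by MTT assay, with a stated time of 72 h (on this read-out lower numbers stand for stronger inhibition and higher numbers for weaker inhibition), three compounds built on a shared core have numbers so far. Compound 1 `O=C1c2c[n+]([O-])c3ccccc3c2C(=O)c2c1c1ccccc1n2Cc1cn([C@@H]2C[C@H](O)[C@@H](CO)O2)nn1` gives 630 nM, compound 2 `CN1CCN(CCCCn2c3c(c4ccccc42)C(=O)c2c[n+]([O-])c4ccccc4c2C3=O)CC1` gives 80 nM, and compound 3 `O=C1c2c[n+]([O-])c3ccccc3c2C(=O)c2c1c1ccccc1n2CCN1CCCCC1` gives 1050 nM. Compound 3 thus sits at the upper end of this small set alongside compound 1, the two being within the usual scatter of each other, while compound 2 lies far lower.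

The unmeasured compound 4 `O=C1c2c[n+]([O-])c3ccccc3c2C(=O)c2c1c1ccccc1n2Cc1cn(C[C@@H](O)CO)nn1` keeps the core of compound 3 but has 1-(2,3-dihydroxypropyl)-1H-1,2,3-triazol-4-yl in place of (piperidin-1-yl)methyl, on a saturated chain carbon bound to an aromatic nitrogen: 1-(2,3-dihydroxypropyl)-1H-1,2,3-triazol-4-yl in place of (piperidin-1-yl)methyl on a saturated chain carbon bound to an aromatic nitrogen.

For the measured compounds named here, only one measured step bears directly on this part of the molecule. It is large, a 13-fold higher number from compound 2 to compound 3 (1.12 log units; beyond the scatter), so a change here can move the number a long way, and the range must stay wide. The closest guide is compound 1, which also carries a 1H-1,2,3-triazol-4-yl group with hydroxyl groups further out and gives 630 nM. On that basis, no step beyond the scatter is expected in this assay. The expected step is a 1.5-fold lower number from compound 3 to compound 4 (0.18 log units; within the scatter). For compound 4 the estimated value is 700 nM, with an expected range of 250 nM to 2000 nM.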

Compound 4, half-maximal inhibitory concentration: 490 nM
Compound 4: the middle estimate sits 1.4-fold (0.15 log units) above what was measured; the range from low to high includes it.
By their numbers in this assay, from the lowest: compound 2; then compounds 4, 1 and 3 (each within the scatter of the next, the first and the last beyond it).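

In this assay, 1-(2,3-dihydroxypropyl)-1H-1,2,3-triazol-4-yl in place of (piperidin-1-yl)methyl gives a 2.1-fold lower number from compound 3 to compound 4 (0.33 log units; beyond the scatter) and lies just beyond the scatter, so this triazole arm with its hydroxyl groups can sit on the saturated chain carbon bound to an aromatic nitrogen without the number rising. The far end of the arm makes little visible difference: 2,3-dihydroxypropyl in place of 4-hydroxy-5-(hydroxymethyl)oxolan-2-yl on an aromatic nitrogen gives a 1.3-fold lower number from compound 1 to compound 4 (0.11 log units; within the scatter) and stays within the scatter, so the open chain and the ring cannot be told apart here. The 3-(4-methylpiperazin-1-yl)propyl chain still holds the lowest number of the set, since putting the triazole arm in its place gives a 6.1-fold higher number from compound 2 to compound 4 (0.79 log units; beyond the scatter) and this step is also beyond the scatter.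

On these data alone, it remains open whether the 4-methylpiperazin-1-yl group or the length of the chain carrying it sets that low number, and how a morpholine or a carboxylic acid at the end of the chain would read. No further data here account for the size of these steps.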